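Carboxyphenoxymethyl acid placement on a bile acid receptor agonist

The source may hold more compounds than are shown below. What is called first, only, known or untested is meant among the compounds shown, and "the series" means these compounds.

Measured so far:
compound 1 `CN(Cc1ccc(C(=O)O)cc1)c1ccc(OCc2c(-c3c(Cl)cccc3Cl)noc2C2CC2)nc1C(F)(F)F`: 30 nM
compound 2 `O=C(O)c1ccccc1OCc1ccc(OCc2c(-c3c(Cl)cccc3Cl)noc2C2CC2)nc1C(F)(F)F`: 1710 nM
compound 3 `O=C(O)c1cccc(OCc2ccc(OCc3c(-c4c(Cl)cccc4Cl)noc3C3CC3)nc2C(F)(F)F)c1`: 151 nM

All numbers come from a functional assay on HEK293 cells for agonist activity at Bile acid receptor (Homo sapiens); on this read-out lower numbers stand for an effect already at smaller amounts and higher numbers for an effect only at larger amounts of compound. Compound 3 stands second of the three: a 5.0-fold higher number from compound 1 to compound 3 (0.70 log units; beyond the scatter), while an 11-fold lower number from compound 2 to compound 3 (1.05 log units; beyond the scatter). The next compound, compound 4 `O=C(O)c1ccc(OCc2ccc(OCc3c(-c4c(Cl)cccc4Cl)noc3C3CC3)nc2C(F)(F)F)cc1`, keeps the whole skeleton and differs only in 4-carboxyphenyl in place of 3-carboxyphenyl on an oxygen on a saturated carbon. The step that bears on this is the earlier move of the acid around the same ring, an 11-fold lower number from compound 2 to compound 3 (1.05 log units; beyond the scatter), a large gain. The comparison with compound 1, which carries its acid in the 4-position of a benzyl group on a different linker, is a 5.0-fold higher number from compound 1 to compound 3 (0.70 log units; beyond the scatter). A modest further lowering is therefore expected, a 2.5-fold lower number from compound 3 to compound 4 (0.40 log units; beyond the scatter). Compound 4 is estimated at 60 nM, with a range of 15 nM to 250 nM.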

Compound 4, half-maximal effective concentration: 95 nM
For compound 4 the middle estimate is 1.6-fold (0.20 log units) below the measured one; low and high end bracket the measured number.
By their numbers in this assay, from the lowest: compound 1; then compounds 4 and 3 (each within the scatter of the next); then compound 2.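

On the oxygen on a saturated carbon, 4-carboxyphenyl and 3-carboxyphenyl are not separated (a 1.6-fold lower number from compound 3 to compound 4 (0.20 log units; within the scatter)), while the change from 2-carboxyphenyl carries a clear gain (an 18-fold lower number from compound 2 to compound 4 (1.26 log units; beyond the scatter)). Even with 4-carboxyphenyl, the (4-carboxyphenoxy)methyl group does not match the (4-carboxybenzyl)(methyl)amino group of compound 1 (a 3.2-fold higher number from compound 1 to compound 4 (0.50 log units; beyond the scatter)). No measurement on hand accounts for these differences.

Open, going by these compounds, is whether a tetrazole could replace the carboxylic acid of 4-carboxyphenyl with the number held. Also open, on these data alone, is how a longer chain between the oxygen and 4-carboxyphenyl would read.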